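The source may hold more compounds than are shown below. What is called first, only, known or untested is meant among the compounds shown, and "the series" means these compounds.

Values in a functional assay on HUVEC cells (Homo sapiens) for antiproliferative activity, read by MTT assay, with a stated time of 24 h; a higher number here means a weaker inhibitor, a lower number a stronger inhibitor:
- compound 1 `COc1cc(OC)c(-c2coc3cc(OCC(=O)c4cccc(C(F)(F)F)c4)ccc3c2=O)cc1OC`: > 10000 nM (a limit of the assay, not a number)
- compound 2 `COc1cc(OC)c(-c2coc3cc(OCc4ccc(F)cc4)ccc3c2=O)cc1OC`: > 10000 nM (a limit of the assay, not a number)
- compound 3 `COc1cc(OC)c(-c2coc3cc(OCc4ccccc4C)ccc3c2=O)cc1OC`: 4830 nM

In this assay, going by the values given here, compound 3 gives 4830 nM, the only true number in the set and the strongest result so far. The other two compounds rest at the limit of > 10000 nM in this assay, at which 2 of the 3 values shown sit.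

Compound 4 `COc1cc(OC)c(-c2coc3cc(OCc4cccc(F)c4)ccc3c2=O)cc1OC` has not yet been measured. It differs from compound 3 by 3-fluorophenyl in place of 2-methylphenyl on a saturated chain carbon bound to an oxygen on an aromatic ring: 3-fluorophenyl stands in place of 2-methylphenyl on a saturated chain carbon bound to an oxygen on an aromatic ring.

The closest evidence is an at least 2.0-fold lower number from compound 2 to compound 3 (0.31 log units; beyond the scatter), since compound 2 also carries a fluorinated ring, 4-fluorophenyl. The second measured step, an at least 2.0-fold lower number from compound 1 to compound 3 (0.31 log units; beyond the scatter), likewise favours 2-methylphenyl, though over a more different group. The third, a step that the two limits leave unreadable from compound 1 to compound 2, adds nothing. Among the compounds with values here, no measured compound carries 3-fluorophenyl, so the comparison with compound 2 is only an approximate guide.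

Losing 2-methylphenyl is therefore expected to raise the number in this assay, and the estimated change is a 1.9-fold higher number from compound 3 to compound 4 (0.27 log units; within the scatter). A result at the limit of the assay would not be surprising. For compound 4 the expected value is 9000 nM. The estimated range for compound 4 runs from 4500 nM to 20000 nM.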

Compound 4, half-maximal inhibitory concentration: 5300 nM
Compound 4: the middle estimate sits 1.7-fold (0.23 log units) above what was measured; low and high end bracket the measured number.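

In this assay, 3-fluorophenyl in place of 2-methylphenyl gives a 1.1-fold higher number from compound 3 to compound 4 (0.04 log units; within the scatter), so at this position, on a saturated chain carbon bound to an oxygen on an aromatic ring, a true number does not depend on the 2-methylphenyl group. Against 4-fluorophenyl the change is an at least 1.8-fold lower number from compound 2 to compound 4 (0.27 log units; that floor lies within the scatter), and against (3-(trifluoromethyl)phenyl)carbonyl it is an at least 1.8-fold lower number from compound 1 to compound 4 (0.27 log units; that floor lies within the scatter); both are floors, so neither gap is shown beyond the scatter, although the true gaps may be larger. Compound 1 and compound 2 each give only a limit of the assay, not a number, so the size of these two gaps stays unknown: the limit of > 10000 nM in this assay, at which 2 of the 4 values shown sit.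

The compounds shown leave open whether the place of the fluorine on the ring matters, since the only comparison of 3-fluorophenyl with 4-fluorophenyl rests on a limit. They also leave open how an unsubstituted phenyl, a 3-methylphenyl or a ring bearing an amine would compare with compound 3 and compound 4 in this assay.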